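Swapping Fluoro for Methoxycarbonyl in a Cytotoxicity Series

This account rests on a few compounds, and the source may have more. Where it says the series, first, only, none or still open, it means among the compounds named here.

In a functional assay on COLO 320 cells (Homo sapiens) for cytotoxicity, read by WST assay, with a stated time of 72 h (a lower number here means a stronger inhibitor, a higher number a weaker inhibitor), compound 3 (`Fc1ccc(-c2cc(-c3ccc4[nH]ccc4c3)on2)cc1`) gives 13900 nM, the only result among the three measured compounds that is a number rather than a limit. Compound 1 (`Cn1c(-c2cc(-c3cccc(F)c3)on2)cc2ccccc21`) reaches only > 100000 nM, which is a limit of the assay. Compound 2 (`COc1cccc(-c2cc(-c3cc4ccccc4n3C)on2)c1`) likewise reaches only > 100000 nM, again a limit. The series thus rests on (the limit of > 100000 nM in this assay, at which 2 of the 3 values shown sit), with compound 3 alone yielding a measured half-maximal inhibitory concentration. Compound 4 (`COC(=O)c1ccc(-c2cc(-c3ccc4[nH]ccc4c3)on2)cc1`) carries methoxycarbonyl in place of fluoro on an aromatic carbon, methoxycarbonyl in place of fluoro on an aromatic carbon. Going by the values given here, no step between measured compounds exists to gauge such a change, so the author expects the step from compound 3 to compound 4 in this assay to be a 1.4-fold higher number from compound 3 to compound 4 (0.16 log units; within the scatter), a slight weakening that may not exceed the scatter. Compound 4 is therefore estimated at 20000 nM, with a range from 6000 nM to 70000 nM.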

Compound 4, half-maximal inhibitory concentration: > 100000 nM
Compound 4 was reported as a limit; the forecaster's own chance of this, stated with the estimate: 25%; middle value at least 5.0-fold (0.69 log units) away from the limit.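

In this assay, going by these compounds alone, methoxycarbonyl in place of fluoro at this position, para to a large group, gives an at least 7.1-fold higher number from compound 3 to compound 4 (0.85 log units; beyond the scatter), the first step that can be read and one beyond the scatter. Compound 4 gives > 100000 nM, which is a limit and not a number, so the step fixes only a lowest size. Of these two groups, only fluoro leaves a measured number, and the series now sits mostly at one limit: the limit of > 100000 nM in this assay, at which 3 of the 4 values shown sit.

From the compounds shown here alone, how far the step really reaches stays open. So does whether an amine, a carboxylic acid or a plain hydrogen at this position would give a measured number in this assay.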